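The source may report more compounds than this note shows. Statements on the series, on what has been measured and on what is new or still open speak of the compounds shown alone.

Among the compounds with values here, in a functional assay on FM3A cells (Mus musculus) for cytotoxicity (on this read-out lower numbers stand for an effect already at smaller amounts and higher numbers for an effect only at larger amounts of compound), compound 1 `C=C(C)COOC1(OOC)CCCCCCCCCCC1` gives 17000 nM and compound 2 `COOC1(OOCCCCCC(=O)O)CCCCCCCCCCC1` gives 14000 nM so compound 2 stands level with the only other measured number. Compound 3 `COOC1(OOCCC(=O)O)CCCCCCCCCCC1` alters compound 2 by carboxy in place of 3-carboxypropyl on a saturated chain carbon, two bonds along the chain from an oxygen with carboxy in place of 3-carboxypropyl on a saturated chain carbon, two bonds along the chain from an oxygen. Within the data shown here, the one measured step of a 1.2-fold lower number from compound 1 to compound 2 (0.08 log units; within the scatter) exchanged a group on this same side chain and stayed within the scatter, so no shift beyond the scatter is expected here. The estimated move is a 1.1-fold higher number from compound 2 to compound 3 (0.06 log units; within the scatter) in this assay overall. For compound 3 the expected value is 16000 nM within an estimated range from 7000 nM to 38000 nM.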

Compound 3, half-maximal effective concentration: 450 nM
Estimate against measurement, compound 3: 36-fold (1.55 log units) above, and the stated range ends above it.
By their numbers in this assay, from the lowest: compound 3; then compounds 2 and 1 (each within the scatter of the next).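

In this assay, the side chain looked insensitive until carboxy replaced 3-carboxypropyl, which gives a 31-fold lower number from compound 2 to compound 3 (1.49 log units; beyond the scatter). Carboxymethyl in place of 1-methylethenyl likewise gives a 38-fold lower number from compound 1 to compound 3 (1.58 log units; beyond the scatter), while compound 2 also ends in a carboxylic acid, so among these compounds the acid alone does not set the number and the length of the chain carrying it matters. Nothing measured here explains the change. On these data alone, whether an amine or an alcohol on the same short chain would behave alike stays open. So does how chain lengths intermediate between those of compound 3 and compound 2 would read.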